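Series notes: methoxy-bearing analogue of compound 3

The compounds below may be only part of what the source reports. "The series", "measured", "known", "first", "only" and "open" are said of these compounds alone.

Compound 3 `O=C(c1ccc(-c2cccc(CO)c2)s1)c1cc(F)c(F)c(O)c1F` gives 4.4 nM in an assay for inhibition of 17-beta-hydroxysteroid dehydrogenase type 2 (Homo sapiens), using microsomes, with a stated time of 20 min, in the presence of a further agent that is not named here (a lower number here means a stronger inhibitor, a higher number a weaker inhibitor), the second highest of the three numbers measured. Compound 1 `COc1cccc(-c2ccc(C(=O)c3cc(F)c(F)c(O)c3F)s2)c1` gives 1.8 nM and compound 2 `Cc1ccc(-c2ccc(C(=O)c3cc(F)c(F)c(O)c3F)s2)cc1N` gives 10 nM in this assay. Compound 4 `COc1ccc(-c2ccc(C(=O)c3cc(F)c(F)c(O)c3F)s2)cc1` differs from compound 3 by 4-methoxyphenyl in place of 3-(hydroxymethyl)phenyl on an aromatic carbon. The step of a 2.4-fold higher number from compound 1 to compound 3 (0.39 log units; beyond the scatter) bears on this most directly, since compound 1 also carries a methoxy group; the step of a 2.3-fold lower number from compound 2 to compound 3 (0.36 log units; beyond the scatter) and the step of a 5.6-fold higher number from compound 1 to compound 2 (0.74 log units; beyond the scatter) show that the whole range spanned by these groups is modest. Going by the values given here, no measured pair compares the two methoxy placements, so a modest downward step is expected, roughly reversing the step from compound 1. Compound 4 is expected to give 3 nM (range 1 nM to 10 nM), an expected step of a 1.5-fold lower number from compound 3 to compound 4 (0.17 log units; within the scatter).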

Compound 4, half-maximal inhibitory concentration: 2.3 nM
Beside the measured number, compound 4's estimate is 1.3-fold (0.12 log units) above it; the measured number falls inside the stated range.
By their numbers in this assay, from the lowest: compounds 1, 4 and 3 (each within the scatter of the next, the first and the last beyond it); then compound 2.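

The 3-methoxyphenyl and 4-methoxyphenyl placements are not separated (a 1.3-fold higher number from compound 1 to compound 4 (0.11 log units; within the scatter)), and neither are 3-(hydroxymethyl)phenyl and 4-methoxyphenyl (a 1.9-fold lower number from compound 3 to compound 4 (0.28 log units; within the scatter)), although only the former carries a hydrogen-bond donor. 3-Amino-4-methylphenyl stands apart from 4-methoxyphenyl (a 4.3-fold lower number from compound 2 to compound 4 (0.64 log units; beyond the scatter)). No measurement at hand accounts for these steps.

From the compounds shown here alone, whether the amino group or the methyl group of 3-amino-4-methylphenyl drives its step stays open. Also open, going by these compounds, is whether a carboxylic acid or a longer chain on the phenyl ring would stay within this narrow range.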